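Isobutyl Sulfone in Place of a Sulfonamide

The source may hold more compounds than are shown below. What is called first, only, known or untested is meant among the compounds shown, and "the series" means these compounds.

Measured so far:
- compound 1 `COCCN(C)S(=O)(=O)c1ccc(C)c(C#Cc2cc(Cl)ccc2OCC(=O)O)c1`: 4.1 nM
- compound 2 `CS(=O)(=O)c1cccc(C#Cc2cc(Cl)ccc2OCC(=O)O)c1`: 15 nM

In an assay on CHO cells for displacement of a labelled ligand from prostaglandin D2 receptor 2 (Homo sapiens), read by scintillation counting (a higher number here means a weaker inhibitor, a lower number a stronger inhibitor), compound 1 gives 4.1 nM, the lower of the two numbers and so the stronger inhibitor of the pair. Compound 2 gives 15 nM in this assay, a higher number that lies beyond the usual scatter of repeats. Compound 3 `Cc1ccc(S(=O)(=O)CC(C)C)cc1C#Cc1cc(Cl)ccc1OCC(=O)O` has not yet been measured. It differs from compound 1 in one place: isobutyl in place of (2-methoxyethyl)(methyl)amino on a sulfonyl sulfur. For the measured compounds named here, no measured pair shows this exact change, so the expectation rests on the two values given. Compound 2, which also carries a carbon chain rather than a nitrogen on its sulfonyl sulfur, gives 15 nM, and on that basis a modest rise in the number is expected, an estimated step of a 2.0-fold higher number from compound 1 to compound 3 (0.29 log units; within the scatter), close to the edge of the scatter. Compound 3 is therefore estimated at 8 nM, with a likely range from 2.5 nM to 25 nM.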

Compound 3, inhibition constant: 3 nM
Compound 3: middle estimate off by 2.7-fold (0.43 log units), on the high side, and the stated range covers the measured number.
By their numbers in this assay, from the lowest: compounds 3 and 1 (each within the scatter of the next); then compound 2.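

In this assay, putting isobutyl in place of (2-methoxyethyl)(methyl)amino on the sulfonyl sulfur gives a 1.4-fold lower number from compound 1 to compound 3 (0.14 log units; within the scatter), so this change makes no readable difference to the number. For the compounds shown here, this is the first direct view of this position: the sulfonyl sulfur can carry a plain carbon chain instead of a nitrogen-linked group, and the nitrogen and oxygen of the group that leaves are not needed to keep the number in this range. Nothing measured here explains why the two groups give such similar numbers.

Compound 2 differs from compound 3 in more than one place, so it cannot show how much the isobutyl itself contributes. As far as these compounds go, it also remains open whether a longer chain, a cyclopropyl ring or a chain ending in an amine would be accepted on the same sulfur.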